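The source may hold more compounds than are shown below. What is called first, only, known or untested is meant among the compounds shown, and "the series" means these compounds.

Measured in a functional assay on FaDu cells (Homo sapiens) for cytotoxicity, read by MTT assay, with a stated time of 72 h; on this read-out higher numbers stand for lower toxicity in this test and lower numbers for higher toxicity in this test:
compound 1 `COc1ccc(NC(=O)C(=O)c2cn(C(C)C)c3ccccc23)cn1`: 85 nM
compound 2 `COCC(C)n1cc(C(=O)C(=O)Nc2ccc(OC)nc2)c2ccccc21`: 12 nM
compound 3 `COc1ccc(NC(=O)C(=O)c2cn(CC(C)C)c3ccccc23)cn1`: 317 nM

Compound 3 at 317 nM has the highest number of the three, and its gaps to both others lie beyond the scatter. The next entry is compound 4 `COCC(C)(C)n1cc(C(=O)C(=O)Nc2ccc(OC)nc2)c2ccccc21`, with 1-(methoxymethyl)-1-methylethyl in place of isobutyl on an aromatic nitrogen.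

Among the measured compounds shown here, two measured steps bear most directly on this change. The closest is a 26-fold higher number from compound 2 to compound 3 (1.42 log units; beyond the scatter), a large step that removes a methoxy-bearing group and installs isobutyl, so its reverse points to a lower number for compound 4. For the measured compounds named here, the modest step of a 7.1-fold lower number from compound 1 to compound 2 (0.85 log units; beyond the scatter) points the same way, although compound 2 is the only measured compound with a methoxy group on this chain. The modest step of a 3.7-fold higher number from compound 1 to compound 3 (0.57 log units; beyond the scatter) shows that the number also moves between the two groups without methoxy. Going by the values given here, the entering group carries one more methyl than the group in compound 2, and no measured pair tests that difference.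

A step to a lower number is therefore expected, between those two methoxy-related steps in size. The estimated change is a 9.1-fold lower number from compound 3 to compound 4 (0.96 log units; beyond the scatter) in this assay. Compound 4 is expected at 35 nM within an estimated range from 8 nM to 150 nM, pending measurement.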

Compound 4, concentration lethal to 50% of the cells: 137 nM
Compound 4: middle estimate off by 3.9-fold (0.59 log units), on the low side; the measured number falls inside the stated range.
By their numbers in this assay, from the lowest: compound 2; then compounds 1 and 4 (each within the scatter of the next); then compound 3.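

In this assay, the methoxy-bearing chain does not set the number on its own: with the methoxy kept, methyl in place of hydrogen on the chain carbon bound to the aromatic nitrogen gives an 11-fold higher number from compound 2 to compound 4 (1.06 log units; beyond the scatter), a large step and the first measured test of that difference. Against isobutyl, 1-(methoxymethyl)-1-methylethyl still gives a lower number, a 2.3-fold lower number from compound 3 to compound 4 (0.36 log units; beyond the scatter), but this modest step is much smaller than the large one seen with the group of compound 2, a 26-fold higher number from compound 2 to compound 3 (1.42 log units; beyond the scatter). Methoxymethyl in place of hydrogen on the same chain carbon gives a 1.6-fold higher number from compound 1 to compound 4 (0.21 log units; within the scatter), which lies within the scatter, so here the added methoxy-bearing arm brings no clear change, whereas methoxy in place of hydrogen on the isopropyl chain gave a 7.1-fold lower number from compound 1 to compound 2 (0.85 log units; beyond the scatter).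

Nothing at hand explains why the added methyl has so large an effect on the number. The compounds shown leave open whether a hydroxyl or an amine in place of the methoxy, or a longer chain carrying the methoxy, would keep the low number of compound 2 or follow compound 4.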